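Swapping Methyl for Difluorophenyl on the Sulfonamide

The source may hold more compounds than are shown below. What is called first, only, known or untested is meant among the compounds shown, and "the series" means these compounds.

Measured in an assay on isolated protein for binding affinity to phosphatidylinositol 4,5-bisphosphate 3-kinase catalytic subunit beta isoform (Homo sapiens); a higher number here means weaker binding, a lower number tighter binding:
Compound 1 `Nc1ncc(-c2cncc(NS(=O)(=O)c3ccccc3)c2)cn1`: 360 nM
Compound 2 `CC(=O)Nc1cncc(-c2cnc(N)nc2)c1`: > 20000 nM, which is a limit of the assay, not a number.
Compound 3 `CS(=O)(=O)Nc1cncc(-c2cnc(N)nc2)c1`: 5200 nM

Of the two plain numbers, compound 3 stands highest; the gap to its nearest neighbour is a 14-fold higher number from compound 1 to compound 3 (1.16 log units; beyond the scatter). Compound 2 sits at a limit of the assay (the limit of > 20000 nM in this assay, at which 1 of the 3 values shown sits). The step of an at least 3.8-fold lower number from compound 2 to compound 3 (0.58 log units; beyond the scatter) is therefore only a bound.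

Compound 4 `Nc1ncc(-c2cncc(NS(=O)(=O)c3ccc(F)cc3F)c2)cn1` differs from compound 3 by 2,4-difluorophenyl in place of methyl on a sulfonyl sulfur. For the measured compounds named here, the one measured step that bears on this is a 14-fold higher number from compound 1 to compound 3 (1.16 log units; beyond the scatter), which runs the other way: removing a phenyl cost a large amount. As far as these compounds go, putting an aromatic ring back is expected to recover most of that, landing near compound 1 with 360 nM, though the two fluorines are untested. The expected step is a 17-fold lower number from compound 3 to compound 4 (1.24 log units; beyond the scatter). Compound 4 is expected to give 300 nM, within 90 nM to 1000 nM.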

Compound 4, dissociation constant: 220 nM
Compound 4: the middle estimate sits 1.4-fold (0.13 log units) above what was measured; measured number inside the range.
By their numbers in this assay, from the lowest: compounds 4 and 1 (each within the scatter of the next); then compound 3. At a limit, above all of these: compound 2.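

Placing 2,4-difluorophenyl on the sulfonyl sulfur in this assay gives a 24-fold lower number from compound 3 to compound 4 (1.37 log units; beyond the scatter), so the gain at this position is not confined to the plain phenyl of compound 1. The two fluorines bring no change that can be told apart from the scatter: a 1.6-fold lower number from compound 1 to compound 4 (0.21 log units; within the scatter). No measurement shown explains why an aromatic ring at this position gives tighter binding than methyl.

Still open, as far as these compounds go, is whether a ring is needed at all, or whether a saturated cyclohexyl group or a longer chain carrying an amine would serve as well.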